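A butylamide in place of the acid on compound 3

This account rests on a few compounds, and the source may have more. Where it says the series, first, only, none or still open, it means among the compounds named here.

Compound 3 `COc1ccc(C2CNC(=O)C2)cc1OCCCC(=O)O` stands in an assay on isolated protein for inhibition of phosphodiesterase 1 (Bos taurus), read by cGMP accumulation, in the presence of a further agent that is not named here (a higher number here means a weaker inhibitor, a lower number a stronger inhibitor), only at a limit: compound 3 gives > 1000000 nM, which is a limit of the assay and not a number. Compound 1 `CCCCOc1cc(C2CNC(=O)C2)ccc1OC` in this assay gives > 1000000 nM, likewise a limit. Compound 2 `C=C(C)COc1cc(C2CNC(=O)C2)ccc1OC` in this assay gives > 1000000 nM, again a limit. This is summed up by the limit of > 1000000 nM in this assay, at which 3 of the 3 values shown sit. The steps among these three compounds, a step that the two limits leave unreadable from compound 1 to compound 2, a step that the two limits leave unreadable from compound 1 to compound 3 and a step that the two limits leave unreadable from compound 2 to compound 3, are therefore not readable in size.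

Compound 4 `CCCCNC(=O)CCCOc1cc(C2CNC(=O)C2)ccc1OC` differs from compound 3 by butylamino in place of hydroxy on a carbonyl carbon: hydroxy leaves and butylamino enters. For the measured compounds named here, none of the measured steps touches a carbonyl carbon, so none bears directly on this change; what they show is only that three compounds on the shared core all sit at the limit. Compound 4 is therefore expected to sit at the limit as well, and a step that the limit leaves unreadable from compound 3 to compound 4 is expected to be nothing readable. The estimate for compound 4 in this assay is 2000000 nM, with a range from 500000 nM to 10000000 nM, and a high chance that only a limit is reported.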

Compound 4, half-maximal inhibitory concentration: > 1000000 nM
Compound 4 was reported as a limit; the forecaster's own chance of this, stated with the estimate: 85%; the middle value is on the limit's open side.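

In this assay compound 4 gives > 1000000 nM, a limit and not a number. The steps to compound 4 from compound 1 and from compound 3 therefore cannot be read in size. The compounds shown leave open how strongly any of them inhibits, and whether any change on the shared core alters that: the limit of > 1000000 nM in this assay, at which 4 of the 4 values shown sit.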